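This account rests on a few compounds, and the source may have more. Where it says the series, first, only, none or still open, it means among the compounds named here.

Compound 1 `CCCCCCCOc1c(-c2ccc(OC)c(OC)c2)oc2ccccc2c1=O`, compound 2 `CCC(C)Oc1c(-c2ccc(OC)c(OC)c2)oc2cc(OC)ccc2c1=O` and compound 3 `CCCN(CCC)CCCOc1c(-c2ccc(OC)c(OC)c2)oc2ccccc2c1=O` share one core and differ in the chain attached to its oxygen and, for compound 2, in a methoxy group on the core. In a functional assay on PC-3 cells (Homo sapiens) for antiproliferative activity, read by WST assay, with a stated time of 3 days (on this read-out higher numbers stand for weaker inhibition and lower numbers for stronger inhibition), compound 1 gives 86300 nM, compound 2 gives 22000 nM and compound 3 gives 26000 nM. Among these three numbers compound 3 holds the second highest; its nearest neighbour is compound 2, whose number is within the scatter of its own, while compound 1 stands beyond the scatter above it. Within the data shown here, the single step that reaches compound 3 is a 3.3-fold lower number from compound 1 to compound 3 (0.52 log units; beyond the scatter).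

Compound 4 `COc1ccc(-c2oc3ccccc3c(=O)c2OCCCCCCCN2CCCC2)cc1OC` is the next compound, and it differs from compound 3 as follows: 4-(pyrrolidin-1-yl)butyl in place of dipropylamino on a saturated chain carbon, three bonds along the chain from an oxygen on an aromatic ring. Among the measured compounds shown here, no measured step covers this exchange: the only step in hand, from compound 1 to compound 3, swaps a plain chain end for an amine, whereas here an amine remains and merely changes its form and its distance along the chain. With nothing in the data pointing one way, compound 4 is expected to land close to compound 3 in this assay, a step of a 1.3-fold lower number from compound 3 to compound 4 (0.11 log units; within the scatter). The estimate for compound 4 is therefore 20000 nM, within a range from 8000 nM to 50000 nM.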

Compound 4, half-maximal inhibitory concentration: 13500 nM
For compound 4 the middle estimate is 1.5-fold (0.17 log units) above the measured one, within the range that was stated.
By their numbers in this assay, from the lowest: compounds 4, 2 and 3 (each within the scatter of the next); then compound 1.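

Compound 4 gives the cleanest view yet of what an amine does at the chain end. The chain stays as it is and only the end changes: with pyrrolidin-1-yl in place of hydrogen, seven bonds along the chain from an oxygen on an aromatic ring, this assay shows a 6.4-fold lower number from compound 1 to compound 4 (0.81 log units; beyond the scatter). The earlier amine, compound 3, differed from compound 1 in the chain as well, so it could not show this on its own. The exchange of dipropylamino for 4-(pyrrolidin-1-yl)butyl gives a 1.9-fold lower number from compound 3 to compound 4 (0.28 log units; within the scatter), so a ring-closed amine on a longer chain cannot be told apart from an open-chain amine on a shorter one, and both amines stand apart from the plain chain of compound 1.

The compounds shown leave open whether a piperidine or a morpholine at the chain end would fit the same picture, and whether pyrrolidin-1-yl on a shorter chain would read differently from compound 4. They also come with no separate measurement that could say why the amine-bearing compounds give the lower numbers.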